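Methyl on the linker carbon across two cores

The source may hold more compounds than are shown below. What is called first, only, known or untested is meant among the compounds shown, and "the series" means these compounds.

Measured so far:
Compound 1, `O=C(O)CCc1ccc(OCc2nc(-c3ccccc3)no2)cc1`: 1130 nM
Compound 2, `CC(Oc1ccc(CCC(=O)O)cc1)c1nc(-c2ccccc2)no1`: 2390 nM
Compound 3, `O=C(O)CCc1ccc(OCc2nc(-c3ccc(Cl)cc3)no2)cc1`: 540 nM

In a functional assay on CHO cells for agonist activity at Free fatty acid receptor 1 (Homo sapiens), read by FLIPR and calcium flux, in the presence of a further agent that is not named here (a lower number here means that less compound is needed, a higher number that more compound is needed for the effect), compound 3 gives the lowest of the three numbers. From compound 1 to compound 3 the change is chloro in place of hydrogen on an aromatic carbon and the step is a 2.1-fold lower number from compound 1 to compound 3 (0.32 log units; beyond the scatter). From compound 1 to compound 2 the change is methyl in place of hydrogen on a saturated chain carbon bound to an aromatic carbon and an oxygen on an aromatic ring and the step is a 2.1-fold higher number from compound 1 to compound 2 (0.33 log units; beyond the scatter).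

Compound 4, `CC(Oc1ccc(CCC(=O)O)cc1)c1nc(-c2ccc(Cl)cc2)no1`, is not yet measured. It differs from compound 3 by methyl in place of hydrogen on a saturated chain carbon bound to an aromatic carbon and an oxygen on an aromatic ring, the same change as from compound 1 to compound 2. The two cores differ by chloro in place of hydrogen on an aromatic carbon, so the question is whether the methyl step carries over. For the measured compounds named here, with only one prior instance, the expectation for compound 4 rests on that single step, a 2.1-fold higher number from compound 1 to compound 2 (0.33 log units; beyond the scatter), applied to compound 3; a step of a 2.1-fold higher number from compound 3 to compound 4 (0.33 log units; beyond the scatter) is expected. Compound 4 is estimated at 1150 nM, between 500 nM and 2600 nM.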

Compound 4, half-maximal effective concentration: 500 nM
The estimate for compound 4 lay 2.3-fold (0.36 log units) above the measured number; low and high end bracket the measured number.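

In this assay, methyl in place of hydrogen on the saturated chain carbon gives a 1.1-fold lower number from compound 3 to compound 4 (0.03 log units; within the scatter) on the chloro core, while chloro in place of hydrogen on the methyl-bearing core gives a 4.8-fold lower number from compound 2 to compound 4 (0.68 log units; beyond the scatter). The methyl step on the two cores cannot be told apart, although only the step on the unsubstituted core lies beyond the scatter: the same change on two cores in this assay, a 2.1-fold higher number (0.33 log units; beyond the scatter) from compound 1 to compound 2 and a 1.1-fold lower number (0.03 log units; within the scatter) from compound 3 to compound 4, 2.3-fold (0.36 log units) apart, within the scatter of two such steps
The chloro step reads the same way, so these two pairs show no measurable dependence on the core but do not establish that either step carries over reliably: the same change on two cores in this assay, a 2.1-fold lower number (0.32 log units; beyond the scatter) from compound 1 to compound 3 and a 4.8-fold lower number (0.68 log units; beyond the scatter) from compound 2 to compound 4, 2.3-fold (0.36 log units) apart, within the scatter of two such steps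

Going by these compounds, whether the methyl step holds with methoxy or trifluoromethyl in place of chloro remains open. Ethyl in place of methyl on that chain carbon also remains open.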